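Swapping the methylphenyl for a chlorophenyl on the amide arm

The source may hold more compounds than are shown below. What is called first, only, known or untested is meant among the compounds shown, and "the series" means these compounds.

Among the measured compounds shown here, compound 2 `Cc1cccc(CNC(=O)c2nn(-c3ccc(F)cc3)c(OC[C@@H](O)C[C@@H](O)CC(=O)O)c2C(C)C)c1` stands lowest of the three numbers measured so far in an assay on microsomes from liver for inhibition of 3-hydroxy-3-methylglutaryl-coenzyme A reductase (Rattus norvegicus) (a lower number here means a stronger inhibitor, a higher number a weaker inhibitor), where compound 2 gives 4.9 nM. Its nearest neighbour, compound 1 `CC(C)c1c(C(=O)N2CCC[C@H](N3CCC4C=CC=CC4C3)C2)nn(-c2ccc(F)cc2)c1CC[C@@H](O)C[C@@H](O)CC(=O)O`, gives 10 nM, and the furthest, compound 3 `COc1ccc(CNC(=O)c2nn(-c3ccc(F)cc3)c(OC[C@@H](O)C[C@@H](O)CC(=O)O)c2C(C)C)cc1`, gives 12 nM. Compound 4 `CC(C)c1c(C(=O)NCc2ccccc2Cl)nn(-c2ccc(F)cc2)c1OC[C@@H](O)C[C@@H](O)CC(=O)O` differs from compound 2 by a single change: 2-chlorophenyl in place of 3-methylphenyl on a saturated chain carbon bound to an amide-type nitrogen. For the measured compounds named here, the one measured step at the same place is a 2.4-fold higher number from compound 2 to compound 3 (0.39 log units; beyond the scatter), a modest one. Changing the aromatic group on the saturated chain carbon bound to an amide-type nitrogen has so far moved the number only modestly, so compound 4 is expected to show a small step, if any, in this assay, with a weakening somewhat more likely than a strengthening: a 1.4-fold higher number from compound 2 to compound 4 (0.15 log units; within the scatter). Compound 4 is therefore estimated at 7 nM, within a range from 3 nM to 17 nM.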

Compound 4, half-maximal inhibitory concentration: 9.5 nM
Compound 4: middle estimate off by 1.4-fold (0.13 log units), on the low side; the measured number falls inside the stated range.
By their numbers in this assay, from the lowest: compounds 2, 4, 1 and 3 (each within the scatter of the next, the first and the last beyond it).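

In this assay, the 2-chlorophenyl group on a saturated chain carbon bound to an amide-type nitrogen gives a 1.9-fold higher number from compound 2 to compound 4 (0.29 log units; within the scatter) and a 1.3-fold lower number from compound 3 to compound 4 (0.10 log units; within the scatter). Compound 4 thus cannot be told apart from either compound 2 or compound 3, although those two lie beyond the scatter of each other, and a chlorine-bearing ring is tolerated here. Nothing available explains these small steps.

The compounds shown leave open whether an amine or a carboxylic acid on this phenyl ring would also be tolerated. They also leave open what a longer chain between the ring and the amide-type nitrogen would do.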